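The source may hold more compounds than are shown below. What is called first, only, known or untested is meant among the compounds shown, and "the series" means these compounds.

Measured compounds:
compound 1 `N/C(=N/NC(CC(=O)c1ccc(-n2ccnc2)cc1)c1ccc(F)cc1)c1ccccn1` — 78800 nM
compound 2 `N/C(=N/NC(CC(=O)c1ccc(-n2ccnc2)cc1)c1ccccc1[N+](=O)[O-])c1ccccn1` — 48000 nM
compound 3 `N/C(=N/NC(CC(=O)c1ccc(-n2ccnc2)cc1)c1cccc(Br)c1)c1ccccn1` — 51300 nM

All three have been run in an ADME assay on Vero cells (Chlorocebus sabaeus) for cytotoxicity, read by MTT assay, with a stated time of 72 h; a lower number here means that less compound is tolerated, a higher number that more compound is tolerated. Compound 3 has the second highest of the three numbers, but neither of its steps to the others leaves the scatter: a 1.1-fold higher number from compound 2 to compound 3 (0.03 log units; within the scatter), and a 1.5-fold lower number from compound 1 to compound 3 (0.19 log units; within the scatter). The remaining pair is also flat, a 1.6-fold lower number from compound 1 to compound 2 (0.22 log units; within the scatter). The series therefore gives no aryl substituent that clearly changes what the cells tolerate.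

Compound 4 `N/C(=N/NC(CC(=O)c1ccc(-n2ccnc2)cc1)c1cccc(Cl)c1)c1ccccn1` is the next compound. Relative to compound 3 the change is chloro in place of bromo on an aromatic carbon. Among the compounds with values here, no measured step exchanges one halogen for another at the same position, so there is no direct precedent. The steps that do bear on this part of the molecule are the three above, each of which swaps the whole substituted phenyl and each of which stays within the scatter; the step from one halogen to another is a smaller change than any of them. The expectation for compound 4 is a step of no size beyond the scatter, a 1.1-fold higher number from compound 3 to compound 4 (0.03 log units; within the scatter). In this assay compound 4 is expected to give about 55000 nM, estimated to lie between 28000 nM and 105000 nM.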

Compound 4, half-maximal cytotoxic concentration: 68600 nM
Beside the measured number, compound 4's estimate is 1.2-fold (0.10 log units) below it; measured number inside the range.
By their numbers in this assay, from the lowest: compounds 2, 3, 4 and 1 (each within the scatter of the next).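

In this assay, within the data shown here, the exchange of bromo for chloro, on an aromatic carbon meta to a large group, is the only direct halogen exchange at one position, and a 1.3-fold higher number from compound 3 to compound 4 (0.13 log units; within the scatter) shows that this exchange does not leave the scatter. The 3-chlorophenyl group is also not separated from the other two aryl groups it can be compared with: a 1.4-fold higher number from compound 2 to compound 4 (0.16 log units; within the scatter) is one such step and a 1.1-fold lower number from compound 1 to compound 4 (0.06 log units; within the scatter) is the other, so all the aryl exchanges among these four compounds now stay within the scatter and none of the four stands apart. No measurement is available that would explain why these numbers lie so close together.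

On these data alone, whether a carboxylic acid or a dimethylamino group on this aromatic carbon, in place of the halogen, would give a step beyond the scatter remains open. Also open, as far as these compounds go, is how far the tolerated concentration depends on the shared core, which is the same in all four compounds, so these steps say nothing about changes made there.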